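A few compounds are considered here, and "the series" means these few. Any claim that something is new, unique, unknown or untested is made for them only; others in the source may bear on it.

Compound 2 `O=Cc1ccc(-c2cn3ccnc3c(-c3ccc4ncn(C5CCCCC5)c4c3)n2)cc1` is one of three compounds with a shared core that have been run in a physicochemical assay for lipophilicity, using the shake flask method, in phosphate buffer, measured as octanol-water partition, with a stated time of 85 min, at pH 7.4; on this read-out lower numbers stand for lower lipophilicity and higher numbers for higher lipophilicity. In this assay compound 2 gives 1.5, the lowest of the three numbers. Compound 1 `c1ccc(-c2cn3ccnc3c(-c3ccc4ncn(C5CCCCC5)c4c3)n2)cc1` carries a plain phenyl where compound 2 carries the 4-formylphenyl. In this assay compound 1 gives 1.74, and the step of a number 0.24 log units lower from compound 1 to compound 2 (within the scatter) lies within the scatter. Compound 3 `c1cn2cc(-c3ccsc3)nc(-c3ccc4ncn(C5CCCCC5)c4c3)c2n1` gives 1.81; the step of a number 0.31 log units higher from compound 2 to compound 3 (beyond the scatter) is modest but beyond the scatter, whereas a number 0.07 log units higher from compound 1 to compound 3 (within the scatter) is within it.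

Compound 4 `CCc1ccc(-c2cn3ccnc3c(-c3ccc4ncn(C5CCCCC5)c4c3)n2)cc1` has not yet been measured. It differs from compound 2 by ethyl in place of formyl on an aromatic carbon. Among the measured compounds shown here, the only measured step that touches the same position is a number 0.24 log units lower from compound 1 to compound 2 (within the scatter), in which the formyl entered and the number fell slightly, within the scatter. For the measured compounds named here, removing the formyl again and putting an ethyl in its place has no exact counterpart among the measured steps, so the expectation rests on that one small step and on the general run of the numbers. Compound 4 is expected to sit higher than compound 2, with a step of a number 0.70 log units higher from compound 2 to compound 4 (beyond the scatter) estimated in this assay. For compound 4 the estimated value in this assay is 2.2, with a likely range from 1.7 to 2.7.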

Compound 4, partition coefficient: 1.66
Beside the measured number, compound 4's estimate is 0.54 log units above it; the whole stated range lies above it.
By their numbers in this assay, from the lowest: compounds 2, 4, 1 and 3 (each within the scatter of the next, the first and the last beyond it).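

At this aromatic carbon, para to a large group, the exchange of formyl for ethyl gives a number 0.16 log units higher from compound 2 to compound 4 (within the scatter) in this assay, and ethyl in place of hydrogen gives a number 0.08 log units lower from compound 1 to compound 4 (within the scatter), so hydrogen, formyl and ethyl all lie within the scatter of one another, even though the ethyl brings one more carbon and no hydrogen-bond acceptor in place of the formyl's oxygen. Exchanging the whole aromatic group gives a number 0.15 log units lower from compound 3 to compound 4 (within the scatter), so the 4-ethylphenyl of compound 4 cannot be told apart from thiophen-3-yl, whereas 4-formylphenyl stands apart from thiophen-3-yl by a modest step, a number 0.31 log units higher from compound 2 to compound 3 (beyond the scatter). Nothing available here offers an explanation for why these numbers lie so close together.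

The compounds shown leave open whether an amine or a carboxylic acid on this same aromatic carbon, or a chain longer than ethyl, would carry the number beyond the scatter from compound 1. They also leave open whether the same narrow spread would hold if the cyclohexyl group on the shared core gave way to a different group.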